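A few compounds are considered here, and "the series" means these few. Any claim that something is new, unique, unknown or untested is made for them only; others in the source may bear on it.

Measured compounds in an ADME assay on microsomes from liver (Homo sapiens) for metabolic stability, using NADPH, with a stated time of 30 min, tested at 1 uM, in the presence of a further agent that is not named here; on this read-out lower numbers stand for a less stable compound and higher numbers for a more stable compound:
- compound 1 `CC[C@@H]1c2cn[nH]c2C(=O)[C@H](CC)N1S(=O)(=O)c1ccc(Cl)cc1`: 10%
- compound 2 `CC1C(=O)c2[nH]ncc2C(C2CC2)N1S(=O)(=O)c1ccc(C(F)(F)F)cc1`: 62%

Compound 1 stands lowest of these two numbers. The nearest point is compound 2, whose number lies higher by more than the usual scatter, so compound 2 is the more stable of the pair in this assay.

Compound 3 `CC[C@@H]1C(=O)c2[nH]ncc2[C@H](CC)N1S(=O)(=O)c1ccc(Cl)cc1` keeps every atom and bond of compound 1 and differs only in the drawn configuration: the two compounds have the same atoms and bonds and differ only in configuration as drawn: 2 of 2 stereo elements differ (all stereocentres are inverted: mirror images); a stereocentre at a saturated ring carbon is drawn S in compound 1 and R in compound 3; a stereocentre at a saturated ring carbon is drawn R in compound 1 and S in compound 3. For the measured compounds named here, no pair of measured compounds that differ in a single place is available, so the size of such a mirror-image step cannot be read from the data. Enantiomers can be handled differently by liver enzymes, but with nothing shown to point one way, the expected step from compound 1 to compound 3 in this assay is a number 5 percentage points higher from compound 1 to compound 3 (within the scatter), no larger than the scatter, with the range left wide to allow for either direction.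

Compound 3 is therefore estimated to give 15% in this assay, with an expected range from 3% to 45%.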

Compound 3, percent of the compound remaining: 6%
Compound 3: middle estimate off by 9 percentage points, on the high side; measured number inside the range.
By their numbers in this assay, from the lowest: compounds 3 and 1 (each within the scatter of the next); then compound 2.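

In this assay, inverting both stereocentres gives a number 4 percentage points lower from compound 1 to compound 3 (within the scatter), so this mirror-image change shows no difference beyond the ordinary spread of repeat measurements. For the compounds shown here, this is the first step in the set that can be read at a single structural change, and nothing else separates the pair: the fact that compounds 1 and 3 differ only in the configuration as drawn. The configuration at these two ring carbons, inverted together, therefore does not lift the number, with compound 1 at 10% and compound 3 at 6%.

Still open is whether inverting just one of the two stereocentres would matter, since only the full mirror-image change is shown here. Also open, as far as these compounds go, is how the number would respond to a longer chain or an amine in place of either ethyl group on the shared core.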